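The source may hold more compounds than are shown below. What is called first, only, known or untested is meant among the compounds shown, and "the series" means these compounds.

Measured so far:
- Compound 1 `COc1cc(C2Oc3cc([C@H]4Oc5cc(O)cc(O)c5C(=O)[C@@H]4O)ccc3OC2COC(=O)c2cc([N+](=O)[O-])cc([N+](=O)[O-])c2)ccc1O`: in a functional assay on liver (Rattus norvegicus, strain Sprague-Dawley) for inhibition, with a stated time of 1 h (on this read-out lower numbers stand for stronger inhibition and higher numbers for weaker inhibition), compound 1 gives 14600 nM
- Compound 2 `COc1cc(C2Oc3cc([C@H]4Oc5cc(O)cc(O)c5C(=O)[C@@H]4O)ccc3OC2COC(=O)c2ccc([N+](=O)[O-])cc2)ccc1O`: compound 2 gives 12600 nM
- Compound 3 `COc1cc(C2Oc3cc([C@H]4Oc5cc(O)cc(O)c5C(=O)[C@@H]4O)ccc3OC2COC(=O)c2ccccc2)ccc1O`: compound 3 gives 12700 nM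

These three compounds share one core and differ only in the group attached to a carbonyl carbon of an ester. Compound 1 has the highest of the three numbers, but its steps to the others are small: a 1.1-fold lower number from compound 1 to compound 3 (0.06 log units; within the scatter) and a 1.2-fold lower number from compound 1 to compound 2 (0.06 log units; within the scatter), both within the scatter, as is a 1.0-fold higher number from compound 2 to compound 3 (0.00 log units; within the scatter). So across the three, exchanging the group on that carbonyl carbon has not moved the read-out beyond what repeated measurement would give.

Compound 4 `COc1cc(C2Oc3cc([C@H]4Oc5cc(O)cc(O)c5C(=O)[C@@H]4O)ccc3OC2COC(=O)/C=C/c2ccc(Cl)cc2)ccc1O` is the next variation on the same site: 2-(4-chlorophenyl)ethenyl in place of 3,5-dinitrophenyl on a carbonyl carbon. The two steps that bear on this one, from compound 1 to compound 2 and from compound 1 to compound 3, both changed the group on the same carbonyl carbon and both stayed within the scatter. On that basis compound 4 is expected to show a 1.1-fold lower number from compound 1 to compound 4 (0.05 log units; within the scatter), a step not distinguishable from measurement noise. The estimate for compound 4 is 13000 nM, with a range from 6000 nM to 28000 nM.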

Compound 4, half-maximal inhibitory concentration: 12000 nM
Estimate against measurement, compound 4: 1.1-fold (0.03 log units) above; low and high end bracket the measured number.
By their numbers in this assay, from the lowest: compounds 4, 2, 3 and 1 (each within the scatter of the next).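

In this assay, among the compounds shown here, the site on this carbonyl carbon now holds a group of a different kind: the earlier compounds carry a phenyl ring, plain or with nitro groups, whereas 2-(4-chlorophenyl)ethenyl adds an ethenyl link and a chlorine and has no nitro group. Even so, every comparison stays within the scatter (a 1.2-fold lower number from compound 1 to compound 4 (0.09 log units; within the scatter); a 1.1-fold lower number from compound 3 to compound 4 (0.02 log units; within the scatter); a 1.1-fold lower number from compound 2 to compound 4 (0.02 log units; within the scatter)), so among these four compounds the read-out does not respond to the change in this group, whether it is the larger change from 3,5-dinitrophenyl or the change from phenyl or 4-nitrophenyl. Nothing measured here explains why these different groups give numbers so close together.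

All four groups shown contain a six-membered aromatic ring of carbon only, so it remains open whether the same flat response would hold for a group without such a ring, such as a plain alkyl chain, or for one carrying an amine or a carboxylic acid. The ester link and the rest of the shared core are also the same throughout, so these compounds cannot show how the read-out responds to changes in those parts, for example an amide in place of the ester.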